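Acetyl in place of 5-methyl-1,3,4-oxadiazol-2-yl

This account rests on a few compounds, and the source may have more. Where it says the series, first, only, none or still open, it means among the compounds named here.

- compound 1 `O=C(c1cnco1)N1CCC(C(=O)N2N=CC[C@H]2c2ccccc2)CC1` gives 42 mL/min/kg
- compound 2 `Cc1nnc(N2CCC(C(=O)N3N=CC[C@H]3c3ccccc3)CC2)o1` gives 18 mL/min/kg

Among the compounds with values here, in an ADME assay on the whole organism (Rattus norvegicus) for pharmacokinetics, at a dose of 1 mg/kg by the intravenous route (on this read-out higher numbers stand for fast clearance and lower numbers for slow clearance), compound 2 holds the lower of the two numbers, and compound 1 is its only neighbour. Within the data shown here, the single measured step, a 2.3-fold lower number from compound 1 to compound 2 (0.37 log units; beyond the scatter), put 5-methyl-1,3,4-oxadiazol-2-yl in place of (1,3-oxazol-5-yl)carbonyl on an amine nitrogen in a ring. It is modest but lies beyond the scatter.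

Compound 3 `CC(=O)N1CCC(C(=O)N2N=CC[C@H]2c2ccccc2)CC1` carries acetyl in place of 5-methyl-1,3,4-oxadiazol-2-yl on an amine nitrogen in a ring, and the difference counts as follows: acetyl in place of 5-methyl-1,3,4-oxadiazol-2-yl on an amine nitrogen in a ring. Among the measured compounds shown here, this change removes the group that entered in the measured step, so that step is the only guide, and only a partial one, since acetyl is not the group that left. For the measured compounds named here, no compound with acetyl has been measured. A move back towards compound 1 at 42 mL/min/kg is therefore expected, no larger than the measured step. The expected change is a 1.7-fold higher number from compound 2 to compound 3 (0.22 log units; within the scatter), upward in direction. Compound 3 is expected at 30 mL/min/kg, within 15 mL/min/kg to 55 mL/min/kg as the estimated range.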

Compound 3, clearance: 44 mL/min/kg
Compound 3: middle estimate off by 1.5-fold (0.17 log units), on the low side; low and high end bracket the measured number.
By their numbers in this assay, from the lowest: compound 2; then compounds 1 and 3 (each within the scatter of the next).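

The step back to acetyl on the amine nitrogen gave a 2.4-fold higher number from compound 2 to compound 3 (0.39 log units; beyond the scatter) in this assay and so shows that the lower number of compound 2 does not carry over to this smaller group on the same nitrogen. The other new comparison, methyl in place of 1,3-oxazol-5-yl on a carbonyl carbon, gave a 1.0-fold higher number from compound 1 to compound 3 (0.02 log units; within the scatter) and places the two carbonyl-linked compounds within the scatter of each other, so the ring on that carbonyl makes no readable difference in this pair, and among these three compounds only the one with 5-methyl-1,3,4-oxadiazol-2-yl on the nitrogen stands apart, with none going against that. Nothing given here bears on why the number moves with this change.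

The compounds shown leave open whether the lower number depends on the ring being joined directly to the nitrogen, or on the absence of a carbonyl there, or on this particular ring. A 1,3,4-oxadiazole without its methyl, a 1,3-oxazole joined directly to the nitrogen, or a sulfonyl group in the same place could separate these readings.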